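Aryl sulfonate to aryl sulfone on a shared pyrimidine core

This account rests on a few compounds, and the source may have more. Where it says the series, first, only, none or still open, it means among the compounds named here.

Measured compounds:
compound 1 `C[C@@H]1CN(c2nnc(C(F)(F)F)o2)CCN1c1ncc(OCc2ccc(OS(C)(=O)=O)cc2F)cn1` 42 nM
compound 2 `C[C@@H]1CN(C(=O)OC2(C(F)(F)F)COC2)CCN1c1ncc(OCc2ccc(OS(C)(=O)=O)cc2F)cn1` 28 nM

In a functional assay on HEK293S cells for agonist activity at Glucose-dependent insulinotropic receptor (Mus musculus), read by HTRF and cAMP accumulation, with a stated time of 45 min (on this read-out higher numbers stand for an effect only at larger amounts of compound and lower numbers for an effect already at smaller amounts), compound 1 gives 42 nM and compound 2 gives 28 nM. Within the data shown here, the one measured step, a 1.5-fold lower number from compound 1 to compound 2 (0.18 log units; within the scatter), lies within the scatter, so compound 2 and compound 1 cannot be ordered; compound 2 simply carries the lower of the two numbers. Compound 3 `C[C@@H]1CN(C(=O)OC2(C(F)(F)F)COC2)CCN1c1ncc(OCc2ccc(CS(C)(=O)=O)cc2F)cn1` is not yet measured. It differs from compound 2 by (methylsulfonyl)methyl in place of (methylsulfonyl)oxy on an aromatic carbon. Among the measured compounds shown here, neither measured step touches this part of the molecule; the only step known concerns the group on the amine nitrogen in the ring, and it was within the scatter. There is therefore nothing to argue for a shift in either direction, and compound 3 is expected to stay close to compound 2 in this assay, with a 1.3-fold higher number from compound 2 to compound 3 (0.10 log units; within the scatter) as the estimated step. The estimate for compound 3 is 35 nM, with a range from 10 nM to 120 nM.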

Compound 3, half-maximal effective concentration in the Glucose-dependent insulinotropic receptor assay: 140 nM
Estimate against measurement, compound 3: 4.0-fold (0.60 log units) below; measured number above the stated range.
By their numbers in the Glucose-dependent insulinotropic receptor assay, from the lowest: compounds 2 and 1 (each within the scatter of the next); then compound 3.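

In the Glucose-dependent insulinotropic receptor assay putting (methylsulfonyl)methyl in place of (methylsulfonyl)oxy on this aromatic carbon gives a 5.0-fold higher number from compound 2 to compound 3 (0.70 log units; beyond the scatter) and so this position responds to the change, whereas the earlier step on the amine nitrogen gave a 1.5-fold lower number from compound 1 to compound 2 (0.18 log units; within the scatter) and so stayed within the scatter. In a physicochemical assay for solubility, in phosphate buffer, with a stated time of 24 h, at 25 degrees C, at pH 7.4 (a lower number here means a less soluble compound, a higher number a more soluble compound), the same change gives an at least 4.1-fold higher number from compound 2 to compound 3 (0.61 log units; beyond the scatter) and so the two read-outs both carry higher numbers after this one change. In the physicochemical assay compound 3 gives 2500 nM as a measured number. In the physicochemical assay compound 2 gives < 600 nM which is a limit of the assay and not a number: the limit of < 600 nM in the physicochemical assay, at which 1 of the 2 values shown sits.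

The compounds shown leave open how a methylsulfonyl group set directly on the aromatic carbon, or a sulfonamide, would read in the Glucose-dependent insulinotropic receptor assay and so whether the step follows the linking atom or the whole group. They also leave open whether the same change would give a similar step with the 5-(trifluoromethyl)-1,3,4-oxadiazol-2-yl group of compound 1 on the amine nitrogen.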